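The source may report more compounds than this note shows. Statements on the series, on what has been measured and on what is new or still open speak of the compounds shown alone.

In a functional assay on the whole organism (Hindlimb, strain albino) with Mus musculus as the target, in the maximal electroshock model, with a stated time of 0.5 h (on this read-out lower numbers stand for an effect already at smaller amounts and higher numbers for an effect only at larger amounts of compound), compound 1, `O=C(/C=C/c1ccc(Cl)cc1)Nc1nc2ccc(Cl)cc2s1`, gives 204 umol/kg. Compound 2, `CC(=O)N1N=C(Nc2nc3ccc(Cl)cc3s2)CC1c1ccccc1`, gives 161 umol/kg. Among the measured compounds shown here, these two numbers lie within the usual scatter of each other, so compound 1 sits level with the only other measured compound, even though the two structures look quite different.

The next compound, compound 3, `O=C(/C=C/c1ccc(O)cc1)Nc1nc2ccc(Cl)cc2s1`, keeps everything in compound 1 except one substituent. It has hydroxy in place of chloro on an aromatic carbon, para to a large group, turning the 4-chlorophenyl into a 4-hydroxyphenyl: hydroxy in place of chloro on an aromatic carbon.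

For the measured compounds named here, no measured pair here shows this exchange on its own, and the data offer no guide to its direction. The natural starting point is therefore compound 1 at 204 umol/kg, and the expectation in this assay is no step beyond the scatter. The estimated step is a 1.0-fold lower number from compound 1 to compound 3 (0.01 log units; within the scatter), and the wide range reflects how little the two measurements can say. For compound 3 the expected dose is 200 umol/kg, with an estimated range of 90 umol/kg to 450 umol/kg.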

Compound 3, dose for half-maximal effect: 322 umol/kg
For compound 3 the middle estimate is 1.6-fold (0.21 log units) below the measured one; low and high end bracket the measured number.
By their numbers in this assay, from the lowest: compounds 2, 1 and 3 (each within the scatter of the next).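

Among the compounds shown here, this is the first pair in the set that differs in one place only, and in this assay it gives a 1.6-fold higher number from compound 1 to compound 3 (0.20 log units; within the scatter) for hydroxy in place of chloro on the aromatic carbon. The two doses therefore cannot be told apart from the ordinary spread of repeated measurements, even though hydroxy brings a hydrogen-bond donor and a hydrogen-bond acceptor that chloro does not have, so this one pair suggests that the position accepts the exchange without a clear loss or gain. Nothing available here explains this result or adds information beyond the doses themselves.

A single exchange at one position cannot show whether other groups placed there, such as an amine, a methoxy group or a carboxylic acid, would also stay within the scatter or would reach beyond it. On these data alone, it also remains open whether hydroxy in place of the other chloro of compound 1, the one on the shared core, would give a similar result.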